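Aryl Swap on the Triazole Nitrogen of a Spiro Core

The source may report more compounds than this note shows. Statements on the series, on what has been measured and on what is new or still open speak of the compounds shown alone.

Compound 1 `N#CC1=C(N)Oc2c(c3nc4ccccc4nc3c3ccccc23)C12C(=O)N(Cc1cnnn1-c1ccccc1Cl)c1ccccc12` gives 42600 nM in a functional assay on A549 cells (Homo sapiens) for antiproliferative activity, read by MTT assay, with a stated time of 48 h; on this read-out lower numbers stand for stronger inhibition and higher numbers for weaker inhibition.
Compound 2 `CC(=O)Nc1ccc(-n2nncc2CN2C(=O)C3(C(C#N)=C(N)Oc4c3c3nc5ccccc5nc3c3ccccc43)c3ccccc32)cc1` reaches only a limit, > 50000 nM.
Compound 3 `Cc1cccc(-n2nncc2CN2C(=O)C3(C(C#N)=C(N)Oc4c(N)cc5nc6ccccc6nc5c43)c3ccccc32)c1` gives 12300 nM.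

Compound 3 holds the lowest of the two numbers shown; compound 1 sits higher by a gap beyond the scatter, and compound 2 stops at the limit of > 50000 nM in this assay, at which 1 of the 3 values shown sits. Compound 4 `N#CC1=C(N)Oc2c(N)cc3nc4ccccc4nc3c2C12C(=O)N(Cc1cnnn1-c1ccc(Cl)cc1Cl)c1ccccc12` differs from compound 3 in one place: 2,4-dichlorophenyl in place of 3-methylphenyl on an aromatic nitrogen. Among the compounds with values here, the one measured step that also changes the group on the aromatic nitrogen, an at least 1.1-fold higher number from compound 1 to compound 2 (0.06 log units; that floor lies within the scatter), is small and runs into a limit, so the aryl change gives little guidance. Compound 4 is therefore expected to stay near compound 3, with an estimated step of a 1.1-fold higher number from compound 3 to compound 4 (0.02 log units; within the scatter) and an estimate of 13000 nM, between 4000 nM and 45000 nM.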

Compound 4, half-maximal inhibitory concentration: > 50000 nM
Compound 4: no number, only a limit; the forecaster's own chance of this, stated with the estimate: 12%; middle value at least 3.8-fold (0.58 log units) away from the limit.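

In this assay, the aryl group on this aromatic nitrogen proves able to move the read-out on the core of compound 3: 2,4-dichlorophenyl in place of 3-methylphenyl gives an at least 4.0-fold higher number from compound 3 to compound 4 (0.60 log units; beyond the scatter). The earlier aryl change at this position, made on a different core, showed no step beyond the scatter. The value for compound 4 is a limit and not a number, so the full size of the step stays unknown: the limit of > 50000 nM in this assay, at which 2 of the 4 values shown sit.

Which part of the 2,4-dichlorophenyl group matters remains open. So does whether an amine or a carboxylic acid on this aryl ring, or a longer chain in its place, would lower the number.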